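Methyl to trifluoromethyl on the shared core

The source may report more compounds than this note shows. Statements on the series, on what has been measured and on what is new or still open speak of the compounds shown alone.

Measured in a functional assay on CWR22R cells (Homo sapiens) for antiproliferative activity, with a stated time of 96 h; a lower number here means a stronger inhibitor, a higher number a weaker inhibitor:
- compound 1 `Cc1cc(=O)oc2cc(OCC(=O)c3ccc(OC(F)(F)F)cc3)ccc12`: > 100000 nM (a limit)
- compound 2 `Cc1cc(=O)oc2cc(OCC(=O)c3ccc(C(F)(F)F)cc3)ccc12`: > 100000 nM (a limit)

Compound 1 gives no number, only a limit. For the measured compounds named here, the other measured value is a limit too, so the series so far shows (the limit of > 100000 nM in this assay, at which 2 of the 2 values shown sit).

Next is compound 3 `O=C(COc1ccc2c(C(F)(F)F)cc(=O)oc2c1)c1ccc(OC(F)(F)F)cc1`, with the change trifluoromethyl in place of methyl on an aromatic carbon, opposite the ring oxygen. Going by the values given here, the only measured step, a step that the two limits leave unreadable from compound 1 to compound 2, is a different exchange, and it offers no size to carry over to this assay. Compound 1 is only a limit, so any readable result would lie toward stronger inhibition, and another limit remains quite possible. The expected step, toward stronger inhibition and only loosely estimated, is an at least 1.6-fold lower number from compound 1 to compound 3 (0.22 log units; that floor lies within the scatter). The estimated value for compound 3 is 60000 nM, with an expected range of 15000 nM to 200000 nM.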

Compound 3, half-maximal inhibitory concentration: "not active" (no number reported)
The entry for compound 3 holds no number; the estimate stays without a comparison.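

In this assay, for the compounds shown here, compound 3 is reported as "not active" with no number, so no step from compound 1 to compound 3 can be read. The compounds shown leave open whether any change on the shared core gives a readable number, as the series still stands at: the limit of > 100000 nM in this assay, at which 2 of the 3 values shown sit.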